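The source may report more compounds than this note shows. Statements on the series, on what has been measured and on what is new or still open speak of the compounds shown alone.

Three compounds built on one shared core were tested in a functional assay on MCF7 cells (Homo sapiens) for antiproliferative activity, read by XTT assay, with a stated time of 72 h; on this read-out lower numbers stand for stronger inhibition and higher numbers for weaker inhibition. Compound 1 `COc1ccc(-c2cc3ccccc3nc2/C=C/C(=O)c2ccccc2)cc1` gives 4040 nM in this assay. Compound 2 `COc1ccc(-c2cc3ccccc3nc2/C=C/C(=O)c2ccc(F)cc2)cc1` gives 5450 nM. Compound 3 `COc1ccc(C(=O)/C=C/c2nc3ccccc3cc2-c2ccc(OC)cc2)cc1` gives 7380 nM. The three numbers sit close together: a 1.3-fold higher number from compound 1 to compound 2 (0.13 log units; within the scatter), a 1.8-fold higher number from compound 1 to compound 3 (0.26 log units; within the scatter), and a 1.4-fold higher number from compound 2 to compound 3 (0.13 log units; within the scatter). None of these steps leaves the scatter, so compound 3 cannot be set apart from its two companions on the numbers shown; it is simply the compound from which the next step starts.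

Compound 4 `COc1ccc(-c2cc3ccccc3nc2/C=C/C(=O)c2ccc(OC)cc2OC)cc1` differs from compound 3 in one place: methoxy in place of hydrogen on an aromatic carbon. The measured step that most resembles this change also put a methoxy group in place of a hydrogen on an aromatic carbon and brought a 1.8-fold higher number from compound 1 to compound 3 (0.26 log units; within the scatter). The exchange of fluoro for methoxy, a 1.4-fold higher number from compound 2 to compound 3 (0.13 log units; within the scatter), points the same way, as does a 1.3-fold higher number from compound 1 to compound 2 (0.13 log units; within the scatter). On that evidence a further methoxy group is expected to move the number little, if at all, and the step to compound 4 is estimated as a 1.1-fold higher number from compound 3 to compound 4 (0.04 log units; within the scatter). Compound 4 is accordingly expected to give about 8000 nM in this assay, within a range from 3000 nM to 22000 nM.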

Compound 4, half-maximal inhibitory concentration: 6260 nM
The estimate for compound 4 lay 1.3-fold (0.11 log units) above the measured number, within the range that was stated.
By their numbers in this assay, from the lowest: compounds 1, 2, 4 and 3 (each within the scatter of the next).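

In this assay, among these compounds, a methoxy group placed ortho to a large group and meta to a methoxy group, turning 4-methoxyphenyl into 2,4-dimethoxyphenyl, gives a step that stays within the scatter (a 1.2-fold lower number from compound 3 to compound 4 (0.07 log units; within the scatter)), so this place, which carries hydrogen in the earlier compounds, accepts a second methoxy group with no readable change in the number. The whole 2,4-dimethoxyphenyl group on the carbonyl carbon also cannot be told apart from 4-fluorophenyl (a 1.1-fold higher number from compound 2 to compound 4 (0.06 log units; within the scatter)) or from phenyl (a 1.5-fold higher number from compound 1 to compound 4 (0.19 log units; within the scatter)), which means that all four groups shown on that carbon now fall within the scatter of one another. No measurement shown here gives a reason for this lack of separation.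

The compounds shown leave open whether any group at this place can shift the number beyond the scatter, for example an amine, a carboxylic acid or a longer chain such as butoxy. They also leave open whether the methoxy group on the other side of the core, kept unchanged in all four compounds, matters for the number in this assay at all.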